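Ethyl for methyl on the aryl ether of compound 1

A few compounds are considered here, and "the series" means these few. Any claim that something is new, unique, unknown or untested is made for them only; others in the source may bear on it.

Compound 1 `Cc1cccc(OC2CCN(c3ccc(-n4ccnc4)nn3)CC2)c1` stands highest of the three numbers in hand: in an assay on microsomes from liver for inhibition of acyl-CoA desaturase 1 (Rattus norvegicus) (a lower number here means a stronger inhibitor, a higher number a weaker inhibitor), compound 1 gives 251 nM, whereas compound 2 `CC(C)Cc1nnc(-c2ccc(N3CCC(Oc4ccccc4C(F)(F)F)CC3)nn2)s1` gives 37 nM and compound 3 `FC(F)(F)c1ccccc1OC1CCN(c2ccc(-c3nnco3)nn2)CC1` gives 22 nM. For the measured compounds named here, the only step between measured compounds, a 1.7-fold lower number from compound 2 to compound 3 (0.23 log units; within the scatter), exchanges one heteroaryl group for another and leaves the aryl ether untouched. Compound 4 `CCc1cccc(OC2CCN(c3ccc(-n4ccnc4)nn3)CC2)c1` differs from compound 1 only at that aryl ether: methyl in place of hydrogen on a saturated chain carbon bound to an aromatic carbon. Going by the values given here, no measured step bears on this change, so in this assay no step beyond the scatter is expected in either direction. Compound 4 is estimated at 200 nM, with a range from 80 nM to 500 nM. The expected step is a 1.3-fold lower number from compound 1 to compound 4 (0.10 log units; within the scatter).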

Compound 4, half-maximal inhibitory concentration: 38 nM
Beside the measured number, compound 4's estimate is 5.3-fold (0.72 log units) above it, outside the stated range (below it).
By their numbers in this assay, from the lowest: compounds 3, 2 and 4 (each within the scatter of the next); then compound 1.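

The change from 3-methylphenyl to 3-ethylphenyl brings a 6.6-fold lower number from compound 1 to compound 4 (0.82 log units; beyond the scatter) in this assay and so shows that this saturated chain carbon bound to an aromatic carbon is sensitive to one added methyl. The earlier compounds shown here offered no step at this place. Nothing measured here accounts for the size of this step.

Still open, on these data alone, is whether a longer chain such as propyl, or a branched isopropyl, lowers the number further or raises it. Also open, as far as these compounds go, is whether the same step holds with a 1,3,4-oxadiazol-2-yl group in place of the imidazole.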